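The compounds below may be only part of what the source reports. "The series", "measured", "known", "first", "only" and "open" are said of these compounds alone.

Compounds measured in a functional assay on HEK293 cells for antagonist activity at 5-hydroxytryptamine receptor 6 (Homo sapiens), read by cAMP accumulation, with a stated time of 2 h; a higher number here means a weaker inhibitor, a lower number a stronger inhibitor:
- compound 1, `Cc1cc(C)n2nc(NCCCN(C)C)c(S(=O)(=O)c3ccccc3)c2n1`, gives 764 nM
- compound 2, `Cc1cc(C)n2nc(N(C)C)c(S(=O)(=O)c3ccccc3)c2n1`, gives 14.5 nM
- compound 3, `Cc1cc(C)n2nc(N(C)CCN(C)C)c(S(=O)(=O)c3ccccc3)c2n1`, gives 489 nM

Compound 3 stands second highest of the three numbers; its nearest neighbour is compound 1, with a 1.6-fold lower number from compound 1 to compound 3 (0.19 log units; within the scatter), and its farthest is compound 2, with a 34-fold higher number from compound 2 to compound 3 (1.53 log units; beyond the scatter).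

Compound 4, `Cc1cc(C)n2nc([S+](C)[O-])c(S(=O)(=O)c3ccccc3)c2n1`, has not yet been measured. It differs from compound 3 in one place: a group of 3 heavy atoms (1 carbon, 1 oxygen, 1 sulfur; no ring) in place of a group of 7 heavy atoms (5 carbon, 2 nitrogen; no ring), on an aromatic carbon.

For the measured compounds named here, two measured steps bear on this. The step of a 53-fold lower number from compound 1 to compound 2 (1.72 log units; beyond the scatter) and the step of a 34-fold higher number from compound 2 to compound 3 (1.53 log units; beyond the scatter) both show that the shared core carrying a dimethylamino group gives a far lower number than the same core carrying either of the longer amino chains. Going by the values given here, no measured compound carries a group without nitrogen at this position, so the direction of the new step rests on the size of the group alone. Compound 4 is therefore expected to give a lower number than compound 3, estimated as a 4.9-fold lower number from compound 3 to compound 4 (0.69 log units; beyond the scatter), with wide uncertainty. The estimate for compound 4 is 100 nM, in the range 15 nM to 800 nM.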

Compound 4, inhibition constant: 2960 nM
The estimate for compound 4 lay 30-fold (1.47 log units) below the measured number; the whole stated range lies below it.
By their numbers in this assay, from the lowest: compound 2; then compounds 3 and 1 (each within the scatter of the next); then compound 4.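

In this assay the group of 3 heavy atoms (1 carbon, 1 oxygen, 1 sulfur) gives the highest number of the four, so a small group on this aromatic carbon does not by itself bring a low number. Dimethylamino also has 3 heavy atoms, yet replacing it with this group gives a 200-fold higher number from compound 2 to compound 4 (2.31 log units; beyond the scatter) and is the largest of the new steps. Compound 4 also stands above both compounds with longer amino chains (a 6.1-fold higher number from compound 3 to compound 4 (0.78 log units; beyond the scatter) and a 3.9-fold higher number from compound 1 to compound 4 (0.59 log units; beyond the scatter)), so among these four compounds the low number goes with dimethylamino and not with group size alone.

No measurement given here accounts for these steps.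

The compounds shown leave open whether a nitrogen attached directly to this carbon is what matters, as a methoxy group, a methylthio group or a pyrrolidine ring here would help to show.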